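Changing the side group of a weak inhibitor

A few compounds are considered here, and "the series" means these few. Any claim that something is new, unique, unknown or untested is made for them only; others in the source may bear on it.

In a functional assay on HeLa cells (Homo sapiens) for inhibition, read by MTT assay, with a stated time of 48 h (a lower number here means a stronger inhibitor, a higher number a weaker inhibitor), compound 1 (`CCOC(=O)C1=C(N/C=N/c2ncc(-c3ccccc3)s2)Nc2[nH]nc(C)c2C1c1ccc(N(C)C)cc1`) gives 15400 nM and compound 2 (`CCOC(=O)C1=C(N/N=C(/Cl)c2ccc([N+](=O)[O-])cc2)Nc2[nH]nc(C)c2C1c1ccc(N(C)C)cc1`) gives 46200 nM as the higher of the two numbers, which makes it the weaker inhibitor by a gap beyond the usual scatter. Going by the values given here, compound 3 (`CCOC(=O)C1=C(N/C=N/c2ccccn2)Nc2[nH]nc(C)c2C1c1ccc(N(C)C)cc1`) is still unmeasured and differs from compound 2 on an amine nitrogen by a group of 8 heavy atoms (6 carbon, 2 nitrogen; one six-membered aromatic ring with 1 hetero atom) in place of a group of 12 heavy atoms (7 carbon, 2 nitrogen, 2 oxygen, 1 chlorine; one six-membered aromatic ring of carbon only), on an amine nitrogen as its one structural change. Its new group looks closer to that of compound 1, which gives 15400 nM in this assay as well, so a modest fall in the number is expected. The estimated step of a 2.3-fold lower number from compound 2 to compound 3 (0.36 log units; beyond the scatter) is a small one. For compound 3 the estimate is 20000 nM with an expected range from 7000 nM to 60000 nM in this measurement.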

Compound 3, half-maximal inhibitory concentration: 29200 nM
Estimate against measurement, compound 3: 1.5-fold (0.16 log units) below; measured number inside the range.
By their numbers in this assay, from the lowest: compounds 1, 3 and 2 (each within the scatter of the next, the first and the last beyond it).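

Going by these compounds alone, compound 3 allows the first comparisons in which only one place changes. On the amine nitrogen, pyridin-2-yl in place of the group of 12 heavy atoms gives in this assay a 1.6-fold lower number from compound 2 to compound 3 (0.20 log units; within the scatter), and pyridin-2-yl in place of 5-phenyl-1,3-thiazol-2-yl on the double-bonded nitrogen gives a 1.9-fold higher number from compound 1 to compound 3 (0.28 log units; within the scatter), so neither swap moves the number beyond the usual scatter. No measurement shown here accounts for this result. On these data alone, whether an amine or a carboxylic acid carried on the pyridin-2-yl group would give a clearly different number remains open.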